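Swapping the N-Aryl Group: What Compound 3 Might Give

The source may hold more compounds than are shown below. What is called first, only, known or untested is meant among the compounds shown, and "the series" means these compounds.

Two compounds have so far been measured in a functional assay on MDA-MB-231 cells (Homo sapiens) for cytotoxicity, read by MTT assay, with a stated time of 72 h; on this read-out lower numbers stand for stronger inhibition and higher numbers for weaker inhibition:

Compound 1 `COc1cc2c(Oc3ccc(NC(=O)c4nn(-c5ccc(F)cc5)c(=O)c5ccccc45)cc3F)ccnc2cc1OCCCN1CCN(C)CC1` gives 460 nM.
Compound 2 `COc1cc2c(Oc3ccc(NC(=O)c4nn(-c5ccccc5Br)c(=O)c5ccccc45)cc3F)ccnc2cc1OCCCN1CCN(C)CC1` gives 1680 nM.

Compound 2 stands at the higher of the two numbers, with compound 1 the nearest and lower one; the gap between them is the step of a 3.7-fold higher number from compound 1 to compound 2 (0.56 log units; beyond the scatter), which is beyond the scatter. Compound 3 `COc1cc2c(Oc3ccc(NC(=O)c4nn(-c5ccc([N+](=O)[O-])cc5)c(=O)c5ccccc45)cc3F)ccnc2cc1OCCCN1CCN(C)CC1` differs from compound 2 in one place: 4-nitrophenyl in place of 2-bromophenyl on an aromatic nitrogen. Among the compounds with values here, the only measured step that bears on this change is a 3.7-fold higher number from compound 1 to compound 2 (0.56 log units; beyond the scatter), since it alters the same group at the same aromatic nitrogen. The 4-nitrophenyl of compound 3 resembles the 4-fluorophenyl of compound 1 in the name of its single substituent, not the 2-bromophenyl of compound 2. Because compound 1 gives 460 nM, compound 3 is expected to move back toward that number, a step of a 2.6-fold lower number from compound 2 to compound 3 (0.41 log units; beyond the scatter). Compound 3 is therefore estimated at 650 nM, within a range of 250 nM to 1700 nM.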

Compound 3, half-maximal inhibitory concentration: 3490 nM
For compound 3 the middle estimate is 5.4-fold (0.73 log units) below the measured one; the measured number lies above the stated range.
By their numbers in this assay, from the lowest: compound 1; then compound 2; then compound 3.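

With nitro in place of fluoro on an aromatic carbon, this assay shows a 7.6-fold higher number from compound 1 to compound 3 (0.88 log units; beyond the scatter), the largest step among the three compounds, so at this aryl group the number depends on which substituent is present and not only on where it stands. Compound 3 also ends above the 2-bromophenyl compound, with a 2.1-fold higher number from compound 2 to compound 3 (0.32 log units; beyond the scatter), so the two 4-substituted aryl groups fall on opposite sides of compound 2, with compound 1 below it and compound 3 above it. Nothing available here explains these differences.

The compounds shown leave open where an unsubstituted phenyl, a 4-aminophenyl or a 4-methoxyphenyl on this nitrogen would fall. A 2-fluorophenyl or a 4-bromophenyl would also be needed to separate the effect of the halogen's identity from that of its place on the ring.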